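Swapping a chlorophenoxy tail for a phenoxymethyl tail

This account rests on a few compounds, and the source may have more. Where it says the series, first, only, none or still open, it means among the compounds named here.

Compound 1 `Cc1cc(C)c(NC(=O)C(C)(C)CCCCCc2ccccc2)c2c1CC(C)(C)O2` gives 120 nM in an assay for inhibition of acyl-CoA:cholesterol acyltransferase (Oryctolagus cuniculus), using microsomes; a higher number here means a weaker inhibitor, a lower number a stronger inhibitor.
Compound 2 `Cc1cc(C)c(NC(=O)C(C)(C)CCCCOc2ccc(Cl)cc2)c2c1CC(C)(C)O2` gives 330 nM in this assay.

Among the measured compounds shown here, compound 2 stands highest of the two measured numbers; the only measured step is a 2.8-fold higher number from compound 1 to compound 2 (0.44 log units; beyond the scatter), a modest change. Compound 3 `Cc1cc(C)c(NC(=O)C(C)(C)CCCCCOc2ccccc2)c2c1CC(C)(C)O2` differs from compound 2 by phenoxymethyl in place of 4-chlorophenoxy on a saturated chain carbon, five bonds along the chain from a carbonyl carbon. It keeps an oxygen link to the ring but drops the chlorine, so it sits between compound 1 and compound 2 in structure. For the measured compounds named here, only that one step bears on it, and a modest move back toward compound 1 is therefore expected, a 1.7-fold lower number from compound 2 to compound 3 (0.22 log units; within the scatter). Compound 3 is estimated at 200 nM in this assay, with a range of 80 nM to 500 nM.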

Compound 3, half-maximal inhibitory concentration: 86 nM
The estimate for compound 3 lay 2.3-fold (0.37 log units) above the measured number; the measured number falls inside the stated range.
By their numbers in this assay, from the lowest: compounds 3 and 1 (each within the scatter of the next); then compound 2.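

In this assay, phenoxymethyl in place of 4-chlorophenoxy gives a 3.8-fold lower number from compound 2 to compound 3 (0.58 log units; beyond the scatter) and so this place on the chain does respond to the exchange. Phenoxy in place of phenyl gives a 1.4-fold lower number from compound 1 to compound 3 (0.14 log units; within the scatter) and this lies within the scatter, so compound 1 and compound 3 cannot be told apart. Nothing measured here explains either step.

The step from compound 2 changes the chlorine and the length of the tail together, so the two effects cannot be separated. As far as these compounds go, how an amine in place of phenoxymethyl would read remains open.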